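Compound 3 to compound 4: a shorter hydroxy-bearing chain

The source may hold more compounds than are shown below. What is called first, only, known or untested is meant among the compounds shown, and "the series" means these compounds.

Measured in an ADME assay on MT2 cells (Homo sapiens) for cytotoxicity, read by XTT assay, with a stated time of 4 days; on this read-out higher numbers stand for lower toxicity in this test and lower numbers for higher toxicity in this test:
- Compound 1 `Cc1nc(C(NC(=O)C(=O)Nc2ccc(F)c(Cl)c2)C2CCCCN2)sc1CO`: > 77800 nM, a limit.
- Compound 2 `Cc1nc(C(NC(=O)C(=O)Nc2ccc(F)cc2F)C2CCCCN2)sc1CO`: > 110000 nM, a limit.
- Compound 3 `Cc1nc(C(NC(=O)C(=O)NC2CCCCCC2)C2CCCCN2)sc1CCO`: 60000 nM.
- Compound 4 `Cc1nc(C(NC(=O)C(=O)NC2CCCCCC2)C2CCCCN2)sc1CO`: not yet measured.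

Going by the values given here, compound 3 holds the only true number; the other two values are limits. The change is hydroxy in place of hydroxymethyl on a saturated chain carbon bound to an aromatic carbon, read one bond further out as 2-hydroxyethyl to hydroxymethyl. Among the compounds with values here, no measured step covers it. Within the data shown here, the sole step, a step that the two limits leave unreadable from compound 1 to compound 2, lies elsewhere in the structure. Compounds 1 and 2 do carry the 5-(hydroxymethyl)-4-methyl-1,3-thiazol-2-yl of compound 4, but give limits only. Starting from compound 3 at 60000 nM, no step beyond the scatter is expected in this assay. The expected move is a 1.2-fold higher number from compound 3 to compound 4 (0.07 log units; within the scatter). For compound 4 the estimate is 70000 nM, with an expected range of 30000 nM to 140000 nM.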

Compound 4, half-maximal cytotoxic concentration: > 90000 nM
Compound 4 was reported as a limit (the forecaster's own chance of this, stated with the estimate: 35%); middle value at least 1.2-fold (0.10 log units) from the limit.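

In this assay, going by these compounds alone, going from 2-hydroxyethyl to hydroxymethyl gives the first readable step at this position, an at least 1.5-fold higher number from compound 3 to compound 4 (0.17 log units; that floor lies within the scatter). For compound 4, > 90000 nM is a limit, so only the floor of that step is known. The steps from compound 1 and compound 2 to compound 4, which swap the aryl groups for cycloheptyl, cannot be read, as both ends are limits.

On these data alone, whether the step from the 2-hydroxyethyl to the hydroxymethyl compound truly lies beyond the scatter stays open. So does the outcome with an amine, a carboxylic acid or a longer chain in this place.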